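Thiophen-2-yl for 3-Methoxyphenyl: An Expected Loss

This account rests on a few compounds, and the source may have more. Where it says the series, first, only, none or still open, it means among the compounds named here.

Compound 3 `COc1cccc(C2=NN(C(=S)Nc3ccccc3)C(c3ccc4c(c3)OCCO4)C2)c1` stands lowest of the three measured compounds; in a functional assay on HT-29 cells (Homo sapiens) for antiproliferative activity, read by MTT assay, with a stated time of 48 h (on this read-out higher numbers stand for weaker inhibition of growth and lower numbers for stronger inhibition of growth), compound 3 gives 2920 nM. Compound 1 `Fc1ccc(C2=NN(C(=S)Nc3ccccc3)C(c3ccc4c(c3)OCCO4)C2)cc1` gives 37600 nM and compound 2 `COc1ccccc1C1=NN(C(=S)Nc2ccccc2)C(c2ccc3c(c2)OCCO3)C1` gives 30500 nM; the steps were a 13-fold lower number from compound 1 to compound 3 (1.11 log units; beyond the scatter) and a 10-fold lower number from compound 2 to compound 3 (1.02 log units; beyond the scatter), while a 1.2-fold lower number from compound 1 to compound 2 (0.09 log units; within the scatter). Compound 4 `S=C(Nc1ccccc1)N1N=C(c2cccs2)CC1c1ccc2c(c1)OCCO2` differs from compound 3 by thiophen-2-yl in place of 3-methoxyphenyl on a carbon with a double bond to nitrogen. Going by the values given here, no measured step involves thiophen-2-yl, but the two large steps show that the group on this carbon shifts the number strongly, and 3-methoxyphenyl was the only one of the three that gave a low number. Compound 4 is therefore expected to give up part of that advantage, with an estimated step of a 5.1-fold higher number from compound 3 to compound 4 (0.71 log units; beyond the scatter). Compound 4 is estimated at 15000 nM, within 3000 nM to 60000 nM.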

Compound 4, concentration for 50% growth inhibition: 188000 nM
Estimate against measurement, compound 4: 13-fold (1.10 log units) below, outside the stated range (above it).
By their numbers in this assay, from the lowest: compound 3; then compounds 2 and 1 (each within the scatter of the next); then compound 4.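

In this assay compound 4 is the weakest of the four, with a 64-fold higher number from compound 3 to compound 4 (1.81 log units; beyond the scatter) and also a 6.2-fold higher number from compound 2 to compound 4 (0.79 log units; beyond the scatter) and a 5.0-fold higher number from compound 1 to compound 4 (0.70 log units; beyond the scatter) for thiophen-2-yl on this carbon. Going by these compounds alone, the earlier compounds showed only that one group stood out with a low number, whereas this change shows that the number can also rise well beyond those of the 4-fluorophenyl and 2-methoxyphenyl compounds. No measurement at hand accounts for this loss.

The compounds shown leave open whether the low number of compound 3 depends on the methoxy group itself. A 3-ethoxyphenyl or 3-aminophenyl group on this carbon would bear on that.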